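Working notes: from the leucine-type to the methionine-type side chain

The compounds below may be only part of what the source reports. "The series", "measured", "known", "first", "only" and "open" are said of these compounds alone.

Measured in a functional assay on Fem-X cells (Homo sapiens) for cytotoxicity, read by MTT assay, with a stated time of 72 h; on this read-out higher numbers stand for weaker inhibition and lower numbers for stronger inhibition:
- compound 1 `CC1=CCC[C@H]2[C@](C)(CC3=CC(=O)C=CC3=O)[C@@H](C)CC[C@]12C`: 40300 nM
- compound 2 `CC1=CCC[C@H]2[C@](C)(CC3=CC(=O)C=C(N[C@@H](CC(C)C)C(=O)O)C3=O)[C@@H](C)CC[C@]12C`: 10900 nM

Going by the values given here, compound 2 holds the lower of the two numbers, its only neighbour being compound 1. The next structure is compound 3 `CSCC[C@H](NC1=CC(=O)C=C(C[C@]2(C)[C@@H](C)CC[C@]3(C)C(C)=CCC[C@@H]23)C1=O)C(=O)O`, and the change is (methylsulfanyl)methyl in place of isopropyl on a saturated chain carbon, two bonds along the chain from an amine nitrogen and a carbonyl carbon. In words, (methylsulfanyl)methyl stands in place of isopropyl on a saturated chain carbon, two bonds along the chain from an amine nitrogen and a carbonyl carbon.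

Among the compounds with values here, only one measured step bears on this: a 3.7-fold lower number from compound 1 to compound 2 (0.57 log units; beyond the scatter), a modest step that installed the whole (1-carboxy-3-methylbutyl)amino group. Within the data shown here, no measured step varies that chain, so the support is indirect. A smaller step is expected in this assay, probably none beyond the scatter, with no favoured direction, and the anchor is compound 2 at 10900 nM. The expected step is a 1.0-fold higher number from compound 2 to compound 3 (0.00 log units; within the scatter). For compound 3 the estimated value is 11000 nM, within an expected range of 5000 nM to 24000 nM.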

Compound 3, half-maximal inhibitory concentration: 19400 nM
The estimate for compound 3 lay 1.8-fold (0.25 log units) below the measured number, and the stated range covers the measured number.
By their numbers in this assay, from the lowest: compounds 2 and 3 (each within the scatter of the next); then compound 1.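

In this assay, the exchange of isopropyl for (methylsulfanyl)methyl gives a 1.8-fold higher number from compound 2 to compound 3 (0.25 log units; within the scatter) and so does not separate the two side chains on this saturated chain carbon, despite the sulfur atom and the added hydrogen-bond acceptor counted in the entering group. The (1-carboxy-3-(methylsulfanyl)propyl)amino group also gives a 2.1-fold lower number from compound 1 to compound 3 (0.32 log units; beyond the scatter) when it replaces hydrogen on the double-bonded ring carbon, so a step beyond the scatter from compound 1 now appears with two different side chains rather than one. No measurement available here accounts for either step.

The compounds shown leave open whether a side chain bearing an amine, a hydroxyl group or a phenyl ring, or a longer chain, would move this number beyond the scatter of compound 2. They also leave open what the carboxylic acid contributes, since both substituted compounds carry it.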